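The compounds below may be only part of what the source reports. "The series", "measured", "known", "first", "only" and "open" are said of these compounds alone.

Measured compounds in an assay for binding affinity to Alpha-1B adrenergic receptor (Homo sapiens), read by radioligand binding; a higher number here means a weaker inhibitor, a lower number a stronger inhibitor:
Compound 1 `CSc1ccc(C)cc1NCC1=NCCN1` gives 123 nM.
Compound 2 `Cc1ccc(S(C)(=O)=O)c(NCC2=NCCN2)c1` gives 3470 nM.
Compound 3 `CSc1c(F)cccc1NCC1=NCCN1` gives 240 nM.

Compound 1 and compound 2 share a core and differ in one place: methylsulfonyl in place of methylsulfanyl on an aromatic carbon. That change made a 28-fold higher number from compound 1 to compound 2 (1.45 log units; beyond the scatter). Compound 3 carries another core; the difference between the core of compound 3 and the core of compound 1 is not broken down here, and the values of compound 1 and compound 3 lie within the scatter of each other. Compound 4 `CS(=O)(=O)c1c(F)cccc1NCC1=NCCN1` has not yet been measured. It stands to compound 3 as compound 2 stands to compound 1: methylsulfonyl in place of methylsulfanyl on an aromatic carbon. The surroundings are not identical: in compound 1 the place is ortho to a group of 7 heavy atoms and para to a methyl group, whereas in compound 3 it is ortho to a fluoro group and ortho to a group of 7 heavy atoms, so this is the same kind of change rather than the same change. Going by the values given here, a step of comparable size is expected for compound 4, estimated as a 21-fold higher number from compound 3 to compound 4 (1.32 log units; beyond the scatter), because the one measured instance of this change gave a 28-fold higher number from compound 1 to compound 2 (1.45 log units; beyond the scatter). Compound 4 is therefore expected to give about 5000 nM in this assay, estimated to fall between 1500 nM and 15000 nM.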

Compound 4, inhibition constant: 2290 nM
Compound 4: the middle estimate sits 2.2-fold (0.34 log units) above what was measured; the range from low to high includes it.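

In this assay, methylsulfonyl in place of methylsulfanyl on an aromatic carbon again gave a weaker inhibitor on the core of compound 3 (a 9.5-fold higher number from compound 3 to compound 4 (0.98 log units; beyond the scatter)), the same direction as on the core of compound 1. The direction of the change therefore carried from one core to the other, but its size did not, and the two steps cannot be treated as one fixed increment: the same change on two cores in this assay, a 28-fold higher number (1.45 log units; beyond the scatter) from compound 1 to compound 2 and a 9.5-fold higher number (0.98 log units; beyond the scatter) from compound 3 to compound 4, 3.0-fold (0.47 log units) apart, beyond the scatter of two such steps. Going by these compounds alone, with only two pairs, this does not show which difference between the cores goes with the smaller step, whether the fluoro group, the methyl group or something else, nor how large the step would be on a third core.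

The compounds shown leave open how a methylsulfinyl group or a longer chain on the sulfur, such as ethylsulfanyl, would read at this place. They also leave open whether a nitrile or an amide there would give a number nearer to that of the methylsulfanyl or the methylsulfonyl compounds.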